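Lengthening the Chain from Compound 3 to Compound 4

The source may hold more compounds than are shown below. What is called first, only, known or untested is meant among the compounds shown, and "the series" means these compounds.

In a functional assay on T47D cells (Homo sapiens) for antiproliferative activity, read by sulforhodamine B assay, with a stated time of 48 h (a higher number here means a weaker inhibitor of growth, a lower number a stronger inhibitor of growth), compound 3 (`CCCCCCCCC[C@@H](O)[C@@H](N)[C@@H](C)CC`) gives 14000 nM and so stands within the scatter of the two other measured compounds. Compound 1 (`CCCCCCCCCCCCCCC[C@@H](O)[C@@H](N)[C@@H](C)O`) gives 19000 nM in this assay and compound 2 (`CCCCCCCCCCCCCCC[C@@H](O)[C@@H](N)C(C)C`) gives 18000 nM there. Among the compounds with values here, the only measured step in this set is a 1.1-fold lower number from compound 1 to compound 2 (0.02 log units; within the scatter) and it lies within the scatter, but it concerns the swap of isopropyl for 1-hydroxyethyl and not chain length. Compound 4 (`CCCCCCCCCCCCCCC[C@@H](O)[C@@H](N)[C@@H](C)CC`) carries hexyl in place of hydrogen on a saturated chain carbon, ten or more bonds along the chain from an oxygen on a saturated carbon. Within the data shown here, no measured step isolates this change, so the evidence for it is indirect. The chain of compound 4 is also found in compound 1 and in compound 2, and compound 2 at 18000 nM stands within the scatter of compound 3. No step beyond the scatter is therefore expected in this assay for this change. The expected step is a 1.2-fold higher number from compound 3 to compound 4 (0.08 log units; within the scatter) and it would stay within the scatter. For compound 4 the estimated value is 17000 nM with an expected range from 9000 nM to 32000 nM in this measurement.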

Compound 4, concentration for 50% growth inhibition: 17000 nM
Compound 4: the middle estimate sits on the measured number at the digits printed; low and high end bracket the measured number.
By their numbers in this assay, from the lowest: compounds 3, 4, 2 and 1 (each within the scatter of the next).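

Within the data shown here, compound 4 gives the first direct reading of chain length in this assay: hexyl in place of hydrogen on a saturated chain carbon, ten or more bonds along the chain from an oxygen on a saturated carbon, gives a 1.2-fold higher number from compound 3 to compound 4 (0.08 log units; within the scatter) and so leaves the number within the scatter. The compound also gives direct readings at the other end of the molecule, where methyl in place of hydrogen on a saturated chain carbon, three bonds along the chain from an amine nitrogen, gives a 1.1-fold lower number from compound 2 to compound 4 (0.02 log units; within the scatter) and ethyl in place of hydroxy on a saturated chain carbon bound to two saturated chain carbons gives a 1.1-fold lower number from compound 1 to compound 4 (0.05 log units; within the scatter) in the same assay. None of these three changes therefore moves the number beyond the scatter, so neither the added hexyl nor the two exchanges separates these compounds here.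

The compounds shown leave open whether a chain longer than that of compound 4, or an amine or a carboxylic acid in place of the ethyl group, would give a step beyond the scatter. No measurement here speaks to what lies behind these flat readings.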